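The source may report more compounds than this note shows. Statements on the series, on what has been measured and on what is new or still open speak of the compounds shown alone.

For the measured compounds named here, compound 1 `CC(C)(C)N1C[C@@H](C(=O)Nc2nccn2Cc2ccccc2)[C@H](c2ccc(F)cc2F)C1` in a functional assay for agonist activity at Melanocyte-stimulating hormone receptor (Homo sapiens), read by cAMP accumulation (on this read-out higher numbers stand for an effect only at larger amounts of compound and lower numbers for an effect already at smaller amounts), gives 4660 nM, the only number in the set. Compound 2 `CC(C)(C)N1C[C@@H](C(=O)Nc2ncnn2Cc2ccccc2)[C@H](c2ccc(F)cc2F)C1` in this assay gives > 10000 nM, a limit of the assay. Compound 3 `CC(C)(C)N1C[C@@H](C(=O)Nc2nc3ccccc3n2-c2ccccc2)[C@H](c2ccc(F)cc2F)C1` in this assay gives > 10000 nM, also a limit. Compound 1 therefore stands apart from the limit of > 10000 nM in this assay, at which 2 of the 3 values shown sit. Compound 4 `CC(C)(C)N1C[C@@H](C(=O)Nc2nccn2Cc2ccccc2Cl)[C@H](c2ccc(F)cc2F)C1` is not yet measured; against compound 1 it carries chloro in place of hydrogen on an aromatic carbon, that is chloro in place of hydrogen on an aromatic carbon of the benzyl group, ortho to a large group. Going by the values given here, no measured pair in the set carries this change, so its size is open. In this assay the expected step is a 1.3-fold lower number from compound 1 to compound 4 (0.12 log units; within the scatter), within the scatter or slightly toward lower values. Compound 4 in this assay is expected at 3500 nM, with a range of 1200 nM to 10000 nM.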

Compound 4, half-maximal effective concentration: 1270 nM
Estimate against measurement, compound 4: 2.8-fold (0.44 log units) above, and the stated range covers the measured number.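

In this assay, replacing benzyl with 2-chlorobenzyl gives a 3.7-fold lower number from compound 1 to compound 4 (0.56 log units; beyond the scatter). For the compounds shown here, this is the first measured single-place change in the set, and it shows that the benzyl group can carry a chloro at this position without loss, with a modest gain. No other measured pair can be read, and a limit of the assay still marks much of the set: the limit of > 10000 nM in this assay, at which 2 of the 4 values shown sit.

As far as these compounds go, whether a fluoro, a methyl or a methoxy in the same place gives a similar step remains open. So does the effect of an amine or a carboxylic acid on this ring.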